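Nitro for methyl in the cytotoxic series

A few compounds are considered here, and "the series" means these few. Any claim that something is new, unique, unknown or untested is made for them only; others in the source may bear on it.

Measured in a functional assay on SK-N-SH cells (Homo sapiens) for cytotoxicity, read by MTT assay, with a stated time of 24 h; on this read-out higher numbers stand for weaker inhibition and lower numbers for stronger inhibition:
- compound 1 `Cc1ccc(Cc2cn3cc(Cl)ccc3nc2=O)cc1`: 860 nM
- compound 2 `O=c1nc2ccc(Br)cn2cc1Cc1ccc(Cl)cc1`: 940 nM

Compound 1 holds the lowest number of this pair, but with compound 2 beside it the two values lie within the usual scatter of each other, so neither can be ranked. Compound 3 `O=c1nc2ccc(Cl)cn2cc1Cc1ccc([N+](=O)[O-])cc1` is still to be measured. It departs from compound 1 with nitro in place of methyl on an aromatic carbon, para to a large group (nitro in place of methyl on an aromatic carbon). Among the compounds with values here, no step between measured compounds exists, so nothing here shows directly what such an exchange does to the read-out. Within the data shown here, the only guide is the pair of values, compound 1 (860 nM) and compound 2 (940 nM), which sit close together. No direction can be argued from them, and no shift beyond the scatter is expected in this assay for this change. The expected 1.0-fold higher number from compound 1 to compound 3 (0.02 log units; within the scatter) is therefore small. Compound 3 is estimated at 900 nM (expected range 300 nM to 2500 nM).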

Compound 3, half-maximal inhibitory concentration: 940 nM
Estimate against measurement, compound 3: 1.0-fold (0.02 log units) below; the range from low to high includes it.
By their numbers in this assay, from the lowest: compounds 1, 2 and 3 (each within the scatter of the next).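

In this assay, within the data shown here, the exchange of methyl for nitro on an aromatic carbon, para to a large group, gives a 1.1-fold higher number from compound 1 to compound 3 (0.04 log units; within the scatter), and this is the only step that isolates one position. Methyl and nitro differ in heavy atoms and in hydrogen-bond acceptors, yet this read-out does not separate compound 1 from compound 3, so at this position the exchange leaves no effect that can be told from the scatter. No measured evidence is available to interpret this result.

Among these compounds, whether an amine, a carboxylic acid or a longer chain at the same place would also stay within the scatter remains open, since methyl and nitro are the only two groups compared here on an otherwise unchanged core. The exchange also rests on a single pair, so whether it reads the same with other substituents on the shared core is not settled.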